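The source may report more compounds than this note shows. Statements on the series, on what has been measured and on what is new or still open speak of the compounds shown alone.

Compound 1 `Cc1ccc2c(=O)n([C@@H]3O[C@H](COP(=O)(O)OP(=O)(O)OP(=O)(O)O)[C@@H](O)[C@H]3O)ccc2c1` and compound 2 `Cc1ccc2ccn([C@@H]3O[C@H](COP(=O)(O)OP(=O)(O)OP(=O)(O)O)[C@@H](O)[C@H]3O)c(=O)c2c1` are built from the same atoms joined in a different arrangement; the difference between the two cores is not broken down here. Each carries a methyl group on its aromatic ring, and in each that methyl can be exchanged for a chloro group. In a functional assay for agonist activity at P2Y purinoceptor 2 (Homo sapiens), read by FLIPR (a lower number here means that less compound is needed, a higher number that more compound is needed for the effect), compound 1 gives 35 nM, while compound 2 gives 148 nM, so more of compound 2 than of compound 1 is needed to reach the same effect.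

Compound 3 `O=c1c2ccc(Cl)cc2ccn1[C@@H]1O[C@H](COP(=O)(O)OP(=O)(O)OP(=O)(O)O)[C@@H](O)[C@H]1O` is compound 1 with a single change: chloro in place of methyl on an aromatic carbon In this assay compound 3 gives 541 nM, which is a step of a 15-fold higher number from compound 1 to compound 3 (1.19 log units; beyond the scatter).

Compound 4 `O=c1c2cc(Cl)ccc2ccn1[C@@H]1O[C@H](COP(=O)(O)OP(=O)(O)OP(=O)(O)O)[C@@H](O)[C@H]1O` has not yet been measured. It is compound 2 with the same kind of change, at a place described in the same words: chloro in place of methyl on an aromatic carbon Among these compounds this exchange has been seen only once, so the expectation for compound 4 rests on a single step. Because the step of a 15-fold higher number from compound 1 to compound 3 (1.19 log units; beyond the scatter) was large, the number for compound 4 is expected to rise as well, by roughly a 10-fold higher number from compound 2 to compound 4 (1.01 log units; beyond the scatter). Going by these compounds, the two cores are not the same, and whether the exchange acts alike on both is unknown, so the expected range is kept wide. Compound 4 is therefore estimated to give 1500 nM in this assay, somewhere between 400 nM and 6000 nM.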

Compound 4, half-maximal effective concentration: 10 nM
The estimate for compound 4 lay 150-fold (2.18 log units) above the measured number; the measured number lies below the stated range.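

In this assay, exchanging methyl for chloro on an aromatic carbon gives a 15-fold lower number from compound 2 to compound 4 (1.17 log units; beyond the scatter), so less of the chloro compound is needed for the effect, and this runs against the earlier step on the other core: the same change on two cores in this assay, a 15-fold higher number (1.19 log units; beyond the scatter) from compound 1 to compound 3 and a 15-fold lower number (1.17 log units; beyond the scatter) from compound 2 to compound 4, 230-fold (2.36 log units) apart, beyond the scatter of two such steps

In this series, then, a step measured on one core cannot be carried over to the other, since here even its direction is reversed, and the same short description of a change does not guarantee the same outcome. Among the compounds shown here, with only two pairs, this does not show why the steps part ways, whether the reversal follows from the difference between the two cores or from where the group sits on each, or that chloro is generally better or worse than methyl.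

The compounds shown carry only methyl and chloro at these places, so it remains open whether other groups, such as fluoro, bromo, methoxy or an amine, would also pull the two cores in opposite directions. Going by these compounds, it also remains open whether the split seen here is specific to the exchange of methyl for chloro or extends to other changes on these two cores.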